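This account rests on a few compounds, and the source may have more. Where it says the series, first, only, none or still open, it means among the compounds named here.

Measured so far in an assay for inhibition of histone deacetylase 8 (Homo sapiens), read by fluorescence, with stated times of 15 min and 60 min; a higher number here means a weaker inhibitor, a lower number a stronger inhibitor:
compound 1 `Nc1ccccc1NC(=O)c1ccc(CNC2=NC(=O)C(Cc3c[nH]c4ccccc34)N2)cc1`, a limit only: > 20000 nM
compound 2 `Nc1ccccc1NC(=O)c1ccc(CNC2=N[C@H](Cc3ccccc3)CS2)cc1`: 12700 nM
compound 3 `Nc1cc(-c2ccccc2)ccc1NC(=O)c1ccc(CNc2nccc(-c3cccnc3)n2)cc1`, a limit only: > 20000 nM

Compound 3 stands at a limit of this assay, not at a number, so its place among the values shown cannot be fixed more closely than that. One further value shown is also a limit, so compound 3 sits at the limit of > 20000 nM in this assay, at which 2 of the 3 values shown sit, together with compound 1, while compound 2 alone gives a number.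

Compound 4 `Nc1cc(Br)ccc1NC(=O)c1ccc(CNc2nccc(-c3cccnc3)n2)cc1` differs from compound 3 by bromo in place of phenyl on an aromatic carbon, meta to an amino group and para to a large group. Going by the values given here, no step between two measured compounds that differ in one place is available, so nothing here tells how far such a change moves this assay in either direction.

Starting from a limit, a small gain would stay hidden and a loss cannot be read at all. The expectation is therefore no change beyond the scatter, with compound 4 most likely reported as a limit again, a step of a number no higher from compound 3 to compound 4 (the limit leaves the size open). Compound 4 is estimated at 20000 nM, in the range 8000 nM to 50000 nM.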

Compound 4, half-maximal inhibitory concentration: > 20000 nM
Compound 4: no number, only a limit; the forecaster's own chance of this, stated with the estimate: 60%; the middle value lies on the limit itself.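

In this assay compound 4 stands at a limit, as compound 3 does, so the exchange of phenyl for bromo gives no readable step: the limit of > 20000 nM in this assay, at which 3 of the 4 values shown sit.

The compounds shown leave open how far either group moves inhibition, and whether any change at that aromatic carbon would give a number rather than a limit.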